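This account rests on a few compounds, and the source may have more. Where it says the series, first, only, none or still open, it means among the compounds named here.

In an ADME assay on RD cells (Homo sapiens) for cytotoxicity, read by MTT assay, with a stated time of 24 h (a lower number here means that less compound is tolerated, a higher number that more compound is tolerated), compound 3 `CC(CCOc1ccc(-c2noc(C(C)(C)C)n2)cc1)CCN1CCN(c2ccnc(N)c2)C1=O` gives 55000 nM. Going by the values given here, only two compounds have a number here, and compound 2 `Cc1nc(-c2cc(C)c(OCCC(C)CCN3CCN(c4ccnc(N)c4)C3=O)c(C)c2)no1`, with 28800 nM, sits within the scatter of compound 3, so the two cannot be told apart. Compound 1 `CCO/N=C/c1ccc(OCC#CCN2CCN(c3ccnc(N)c3)C2=O)cc1` reaches only a limit, > 100000 nM, in this assay. Compound 4 `CCCc1nc(-c2ccc(OCCC(C)CCN3CCN(c4ccnc(N)c4)C3=O)cc2)no1` differs from compound 3 in a single place: propyl in place of tert-butyl on an aromatic carbon. Among the compounds with values here, no measured pair shows this exact change, so no step can be read off; little movement beyond the scatter is expected in this assay, in either direction. Compound 4 is therefore estimated at 60000 nM, with a range from 20000 nM to 150000 nM, which amounts to an expected step of a 1.1-fold higher number from compound 3 to compound 4 (0.04 log units; within the scatter).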

Compound 4, half-maximal cytotoxic concentration: > 100000 nM
Compound 4: no number, only a limit (the forecaster's own chance of this, stated with the estimate: 30%); middle value at least 1.6-fold (0.22 log units) from the limit.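

At this carbon of the five-membered aromatic ring, replacing tert-butyl with propyl gives, in this assay, an at least 1.8-fold higher number from compound 3 to compound 4 (0.25 log units; that floor lies within the scatter). This first measured pair at the position shows no drop in the number with propyl. Compound 4 has only a limit, so the true size of the step remains unknown and its floor alone does not separate the pair: the limit of > 100000 nM in this assay, at which 2 of the 4 values shown sit.

The compounds shown leave open how an amine, a carboxylic acid or a longer chain at this carbon would read in this assay.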